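Trading a Tetrazolyl Sulfide Ester for an Acetoxy Amide

The compounds below may be only part of what the source reports. "The series", "measured", "known", "first", "only" and "open" are said of these compounds alone.

Compound 3, `CCOc1cc2ncnc(Nc3ccc(F)c(Cl)c3)c2cc1OC(=O)CSc1nnnn1C`, was tested in a functional assay on NCI-H1975 cells (Homo sapiens) for inhibition, read by MTT assay, with a stated time of 72 h (a lower number here means a stronger inhibitor, a higher number a weaker inhibitor), where it gives 2100 nM, the second highest of the three numbers measured. Its nearest neighbour is compound 2, `CCOc1cc2ncnc(Nc3ccc(F)c(Cl)c3)c2cc1OC(=O)CSc1cccnc1`, which gives 3000 nM; the gap a 1.4-fold lower number from compound 2 to compound 3 (0.15 log units; within the scatter) lies within the scatter. The furthest is compound 1, `CCOc1cc2ncnc(Nc3ccc(F)c(Cl)c3)c2cc1OC(=O)CCl`, which gives 60 nM; the step of a 35-fold higher number from compound 1 to compound 3 (1.54 log units; beyond the scatter) is large, as is a 50-fold higher number from compound 1 to compound 2 (1.70 log units; beyond the scatter).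

Compound 4, `CCOc1cc2ncnc(Nc3ccc(F)c(Cl)c3)c2cc1NC(=O)COC(C)=O`, differs from compound 3 in one place: ((acetoxymethyl)carbonyl)amino in place of ((((1-methyl-1H-tetrazol-5-yl)sulfanyl)methyl)carbonyl)oxy on an aromatic carbon. Within the data shown here, no measured step covers this exact exchange. The two measured steps show that replacing the chloro of compound 1 with a (pyridin-3-yl)sulfanyl or a (1-methyl-1H-tetrazol-5-yl)sulfanyl group raised the number greatly, while the step between those two ring groups lay within the scatter. Compound 4 drops the ring entirely and carries a group with no ring, an arrangement closer to compound 1 than to compound 3.

The step of a 5.3-fold lower number from compound 3 to compound 4 (0.72 log units; beyond the scatter) is therefore expected to lower the number, with the size uncertain because the linking atom also changes. Compound 4 is estimated at 400 nM, within a range from 60 nM to 2500 nM.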

Compound 4, half-maximal inhibitory concentration: 3400 nM
Beside the measured number, compound 4's estimate is 8.5-fold (0.93 log units) below it; measured number above the stated range.
By their numbers in this assay, from the lowest: compound 1; then compounds 3, 2 and 4 (each within the scatter of the next).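

In this assay, removing the ring does not bring the number back towards compound 1. The steps of a 1.6-fold higher number from compound 3 to compound 4 (0.21 log units; within the scatter) and a 1.1-fold higher number from compound 2 to compound 4 (0.05 log units; within the scatter) place the ringless compound 4 level with the two ring-bearing sulfides, whereas the step of a 57-fold higher number from compound 1 to compound 4 (1.75 log units; beyond the scatter) leaves it far from compound 1. On this aromatic carbon, a ring in the side group is therefore not needed for a high number, and among these four compounds only the ((chloromethyl)carbonyl)oxy group of compound 1 stands apart. Nothing shown here gives a measured reason for that difference.

The amide link and the change at the end of the chain cannot be separated here, as compound 4 differs from the others in both. As far as these compounds go, how a chloromethyl group on the amide link, or a dimethylamino group at the end of that chain, would compare remains open.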